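The compounds below may be only part of what the source reports. "The series", "measured", "known", "first", "only" and "open" are said of these compounds alone.

Compound 1 `CNc1nc(/C=C/c2cc(OC)c(OC)c(OC)c2)nc2ccsc12`: in a functional assay on L02 cells (Homo sapiens) for inhibition, read by Griess assay, with stated times of 1 h and 24 h (on this read-out higher numbers stand for weaker inhibition and lower numbers for stronger inhibition), compound 1 gives > 1000000 nM, which is a limit of the assay and not a number.
Compound 2 `COc1cc(/C=C/c2nc(NC3CC3)c3sccc3n2)cc(OC)c1OC`: in this assay compound 2 gives > 1000000 nM, again a limit.
Compound 3 `COc1cc(/C=C/c2nc(N3CCN(C)CC3)c3sccc3n2)cc(OC)c1OC`: in this assay compound 3 gives > 1000000 nM, also a limit.

Going by the values given here, compound 3 therefore stands at the same limit as the other two; all three values sit at the limit of > 1000000 nM in this assay, at which 3 of the 3 values shown sit, so no compound can be placed above or below another. The steps between them, a step that the two limits leave unreadable from compound 1 to compound 2, a step that the two limits leave unreadable from compound 1 to compound 3 and a step that the two limits leave unreadable from compound 2 to compound 3, are all unreadable for the same reason: the two limits hide any difference.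

Compound 4 `COc1cc(/C=C/c2nc(Nc3ccc(C(C)C)cc3)c3sccc3n2)cc(OC)c1OC` differs from compound 3 in one place: (4-isopropylphenyl)amino in place of 4-methylpiperazin-1-yl on an aromatic carbon. Among the compounds with values here, no measured step bears on this change in a readable way, since every step in the set is hidden by the limits. The expectation for compound 4 can therefore rest only on the fact that all three measured compounds sit at the limit, and on the change itself; whether an aromatic amine in place of a non-aromatic piperazine ring moves this assay cannot be read from these data. The estimated step from compound 3 to compound 4 is an at least 5.0-fold lower number from compound 3 to compound 4 (0.69 log units; beyond the scatter), given with very wide uncertainty. Compound 4 is estimated at 200000 nM, with a range from 5000 nM to 1000000 nM.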

Compound 4, half-maximal inhibitory concentration: 370000 nM
The estimate for compound 4 lay 1.9-fold (0.27 log units) below the measured number; measured number inside the range.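

In this assay, where a lower number means stronger inhibition, this aromatic carbon next to the ring nitrogen gives its first readable result: (4-isopropylphenyl)amino in place of 4-methylpiperazin-1-yl gives an at least 2.7-fold lower number from compound 3 to compound 4 (0.43 log units; beyond the scatter). The two smaller groups on the nitrogen tell the same story, with 4-isopropylphenyl in place of cyclopropyl giving an at least 2.7-fold lower number from compound 2 to compound 4 (0.43 log units; beyond the scatter) and 4-isopropylphenyl in place of methyl giving an at least 2.7-fold lower number from compound 1 to compound 4 (0.43 log units; beyond the scatter), so the group at this position can move the read-out, though each size is only a minimum. The steps among compound 1, compound 2 and compound 3 still cannot be read, and compound 4 alone carries a number rather than a limit: the limit of > 1000000 nM in this assay, at which 3 of the 4 values shown sit.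

Which part of the new group goes with the lower number stays open: a plain phenylamino group without the isopropyl, or a benzylamino group, could separate the role of the aromatic ring from that of the isopropyl. Also open, from the compounds shown here alone, is whether a longer chain on the nitrogen, such as n-hexylamino, would leave the read-out at the limit or bring it down as well.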